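The source may report more compounds than this note shows. Statements on the series, on what has been measured and on what is new or still open speak of the compounds shown alone.

Compound 1 `O=C(Nc1ccc([N+](=O)[O-])cc1)c1cc(Cl)ccc1O`: 6.4 ug/mL
Compound 2 `COc1cc([N+](=O)[O-])ccc1NC(=O)c1cc(Cl)ccc1O`: 9.2 ug/mL

The read-out for this pair is a physicochemical assay for solubility; on this read-out higher numbers stand for higher solubility and lower numbers for lower solubility. Compound 2 gives 9.2 ug/mL, which lies within the scatter of compound 1 at 6.4 ug/mL, so neither compound stands apart from the other.

Compound 3 `COc1cc([N+](=O)[O-])ccc1NC(=O)c1cc(Br)ccc1O` differs from compound 2 by bromo in place of chloro on an aromatic carbon. The change is bromo in place of chloro on an aromatic carbon, para to a hydroxy group.

For the measured compounds named here, the only measured step is a 1.4-fold higher number from compound 1 to compound 2 (0.16 log units; within the scatter). Going by the values given here, that step is methoxy in place of hydrogen, so it bears only indirectly, and no measured pair exchanges one halogen for another. With so little evidence, no direction can be argued, and no change beyond the scatter is anticipated in this assay. The expected 1.2-fold lower number from compound 2 to compound 3 (0.06 log units; within the scatter) stays within the scatter. Compound 3 is expected at 8 ug/mL, with an estimated range from 3.5 ug/mL to 18 ug/mL.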

Compound 3, solubility: 1.6 ug/mL
Beside the measured number, compound 3's estimate is 5.0-fold (0.70 log units) above it; measured number outside the range, below it.
By their numbers in this assay, from the lowest: compound 3; then compounds 1 and 2 (each within the scatter of the next).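

In this assay the aromatic carbon para to a hydroxy group proves sensitive to its substituent: bromo in place of chloro gives a 5.8-fold lower number from compound 2 to compound 3 (0.76 log units; beyond the scatter), even though the exchange swaps one heavy atom for another and changes no ring, hydrogen-bond count or net charge. For the compounds shown here, the methoxy step, a 1.4-fold higher number from compound 1 to compound 2 (0.16 log units; within the scatter), stayed within the scatter, so this halogen exchange is the first step to go beyond it. Nothing available on these compounds accounts for the size of this step.

Still open, going by these compounds, is whether other groups at this carbon, such as fluoro, an amine or a carboxylic acid, would stay close to compound 2 or fall further. Also open, on these data alone, is whether bromo in place of chloro gives a similar step on the core of compound 1, which lacks the methoxy group.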